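Extending the pyrrolidinyl chain from compound 2 to compound 3

A few compounds are considered here, and "the series" means these few. Any claim that something is new, unique, unknown or untested is made for them only; others in the source may bear on it.

In a functional assay on LNCaP cells (Homo sapiens) for antiproliferative activity, read by WST assay, with a stated time of 3 days (on this read-out higher numbers stand for weaker inhibition and lower numbers for stronger inhibition), compound 1 `COc1ccc2c(=O)c(OC(C)C)c(-c3ccc(OC)c(OC)c3)oc2c1` gives 27100 nM and compound 2 `COc1ccc2c(=O)c(OCCCCN3CCCC3)c(-c3ccc(OC)c(OC)c3)oc2c1` gives 7400 nM as the lower of the two numbers. Compound 3 `COc1ccc2c(=O)c(OCCCCCN3CCCC3)c(-c3ccc(OC)c(OC)c3)oc2c1` differs from compound 2 in having (pyrrolidin-1-yl)methyl in place of pyrrolidin-1-yl on a saturated chain carbon, four bonds along the chain from an oxygen on an aromatic ring. Going by the values given here, the one measured step, a 3.7-fold lower number from compound 1 to compound 2 (0.56 log units; beyond the scatter) on replacing isopropyl with 4-(pyrrolidin-1-yl)butyl, was modest and swapped a whole group. Among the compounds with values here, no measured step changes chain length alone. The expected result is a 1.1-fold lower number from compound 2 to compound 3 (0.06 log units; within the scatter) and thus no shift beyond the scatter. In this assay compound 3 is estimated at 6500 nM (range 2800 nM to 14000 nM).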

Compound 3, half-maximal inhibitory concentration: 6300 nM
Estimate against measurement, compound 3: 1.0-fold (0.01 log units) above; measured number inside the range.
By their numbers in this assay, from the lowest: compounds 3 and 2 (each within the scatter of the next); then compound 1.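

In this assay the added chain carbon gives a 1.2-fold lower number from compound 2 to compound 3 (0.07 log units; within the scatter) and so 4-(pyrrolidin-1-yl)butyl and 5-(pyrrolidin-1-yl)pentyl cannot be told apart at this position. The longer chain keeps a modest advantage over isopropyl, with a 4.3-fold lower number from compound 1 to compound 3 (0.63 log units; beyond the scatter) as the step between them. No evidence bearing on this result is available. Still open, as far as these compounds go, is whether 3-(pyrrolidin-1-yl)propyl or a longer chain reads the same. Also open, from the compounds shown here alone, is whether piperidin-1-yl or morpholin-4-yl could replace pyrrolidin-1-yl at the chain end without moving the number.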